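Chlorine-bearing benzocyclobutyl analogue in alpha-1 adrenergic assay

A few compounds are considered here, and "the series" means these few. Any claim that something is new, unique, unknown or untested is made for them only; others in the source may bear on it.

Going by the values given here, compound 2 `c1ccc2c(c1)CC2CCCN1CCN(c2cccc3c2OCCO3)CC1` gives 0.45 mg/kg in an assay for activation of Adrenergic receptor alpha-1 (Rattus norvegicus) (on this read-out higher numbers stand for an effect only at larger amounts of compound and lower numbers for an effect already at smaller amounts), the lowest of the two numbers in hand; compound 1 `c1ccc2c(c1)CC(CCCN1CCN(c3cccc4c3OCCO4)CC1)C2` gives 1.73 mg/kg in this assay, and the only measured step is a 3.8-fold lower number from compound 1 to compound 2 (0.58 log units; beyond the scatter). Compound 3 `Clc1cccc2c1CC2CCN1CCN(c2cccc3c2OCCO3)CC1` differs from compound 2 by a group of 9 heavy atoms (8 carbon, 1 chlorine; one four-membered non-aromatic ring of carbon only, one six-membered aromatic ring of carbon only) in place of a group of 9 heavy atoms (9 carbon; one four-membered non-aromatic ring of carbon only, one six-membered aromatic ring of carbon only), on a saturated chain carbon, two bonds along the chain from an amine nitrogen in a ring. That measured step concerns a different place and a different exchange, so nothing in hand bears directly on this change. Compound 3 is therefore expected near compound 2, with no step beyond the scatter assumed: the estimate for compound 3 is 0.5 mg/kg, ranging from 0.15 mg/kg to 1.6 mg/kg, a step of a 1.1-fold higher number from compound 2 to compound 3 (0.05 log units; within the scatter).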

Compound 3, dose for half-maximal effect: 20 mg/kg
Beside the measured number, compound 3's estimate is 40-fold (1.60 log units) below it; measured number above the stated range.
By their numbers in this assay, from the lowest: compound 2; then compound 1; then compound 3.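

In this assay this position does not tolerate the exchange: the group of 8 carbon and 1 chlorine brings a 44-fold higher number from compound 2 to compound 3 (1.65 log units; beyond the scatter) and so a large rise. The earlier exchange of the five-membered for the four-membered non-aromatic ring brought only a 3.8-fold lower number from compound 1 to compound 2 (0.58 log units; beyond the scatter) and a modest fall. Nothing measured explains the rise. The compounds shown leave open whether the chlorine or the change in chain accounts for it. As far as these compounds go, a fluorine in place of the chlorine, or a longer chain on the chlorine-bearing group, remains untested here.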